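The source may report more compounds than this note shows. Statements on the series, on what has been measured and on what is new or still open speak of the compounds shown alone.

Compound 1 `Cc1ccc(-c2nn(-c3ccccc3)cc2C(Nc2nc3cc(C)c(C)cc3s2)c2c(O)ccc3ccccc23)cc1` gives 22400 nM in a functional assay on MCF7 cells (Homo sapiens) for antiproliferative activity, read by MTT assay, with a stated time of 48 h; on this read-out lower numbers stand for stronger inhibition and higher numbers for weaker inhibition.
Compound 2 `Cc1cc2nc(NC(c3cn(-c4ccccc4)nc3-c3ccc([N+](=O)[O-])cc3)c3c(O)ccc4ccccc34)sc2cc1C` gives 41100 nM in this assay.

Only these two compounds have been measured, and they differ in a single place; that step is a 1.8-fold higher number from compound 1 to compound 2 (0.26 log units; within the scatter). Compound 2 therefore stands at the highest of the two numbers, but its nearest neighbour, compound 1, sits within the usual scatter of it, so the two cannot be told apart on these data.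

Compound 3 `O=[N+]([O-])c1ccc(-c2nn(-c3ccccc3)cc2C(Nc2nc3ccc(Cl)cc3s2)c2c(O)ccc3ccccc23)cc1` has not yet been measured. Its difference from compound 2 is 6-chloro-1,3-benzothiazol-2-yl in place of 5,6-dimethyl-1,3-benzothiazol-2-yl on an amine nitrogen. For the measured compounds named here, no measured step touches this part of the molecule: the only step available, from one methyl to a nitro group on an aromatic carbon, changes a different ring and stays within the scatter. There is thus nothing in the data that points in either direction for this change, and the expectation in this assay is a step of no size beyond the scatter. The estimated step is a 1.0-fold lower number from compound 2 to compound 3 (0.01 log units; within the scatter). On that basis compound 3 is expected to give about 40000 nM, with a range from 14000 nM to 115000 nM.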

Compound 3, half-maximal inhibitory concentration: 38600 nM
Beside the measured number, compound 3's estimate is 1.0-fold (0.02 log units) above it, within the range that was stated.
By their numbers in this assay, from the lowest: compounds 1, 3 and 2 (each within the scatter of the next).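

In this assay, putting 6-chloro-1,3-benzothiazol-2-yl in place of 5,6-dimethyl-1,3-benzothiazol-2-yl on the amine nitrogen gives a 1.1-fold lower number from compound 2 to compound 3 (0.03 log units; within the scatter), so the two compounds cannot be told apart. For the compounds shown here, this is the first measured step at this part of the molecule, and it shows that, with the nitro group held constant, this particular exchange leaves the read-out within the usual scatter, although the entering group carries a chlorine and the leaving group two methyl groups. Nothing available explains why these two compounds read alike.

As far as these compounds go, the step swaps both methyl groups for one chlorine at once, so what each of these groups contributes alone stays open, and this one exchange says nothing about how a very different group, such as a methoxy group, an amine or a carboxylic acid, would read on the same ring. From the compounds shown here alone, it is also open whether the 6-chloro-1,3-benzothiazol-2-yl group would read the same with a methyl group in place of the nitro group.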